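Chalcone piperazine sulfonamides: a methoxy swap on the aryl ring

The compounds below may be only part of what the source reports. "The series", "measured", "known", "first", "only" and "open" are said of these compounds alone.

Of the compounds shown here, two have been tested in a functional assay on the whole organism (strain Kunming) for inhibition, with Mus musculus as the target, with a stated time of 1 h, at a dose of 40 mg/kg by the oral route; a higher number here means more inhibition at the dose given (going by the name of the read-out), a lower number less inhibition. Compound 1 `O=C(/C=C/c1ccccc1)c1ccc(N2CCN(c3cccc(Cl)c3Cl)CC2)cc1` gives 30.7%, and compound 2 `Cc1ccc(S(=O)(=O)N2CCN(c3ccc(C(=O)/C=C/c4ccccc4)cc3)CC2)cc1` gives 30.8%. The one step between them, a number 0.1 percentage points higher from compound 1 to compound 2 (within the scatter), lies within the scatter, so compound 2 and compound 1 stand at the same level on the numbers shown.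

Compound 3 `COc1ccc(S(=O)(=O)N2CCN(c3ccc(C(=O)/C=C/c4ccccc4)cc3)CC2)cc1OC` remains to be measured. It differs from compound 2 by 3,4-dimethoxyphenyl in place of 4-methylphenyl on a sulfonyl sulfur. Within the data shown here, no measured step touches the group on the sulfonyl sulfur, so there is nothing here that bears directly on this change; the only known step, from the amine nitrogen, was flat. The expectation is therefore a step within the scatter in this assay, a number 0.2 percentage points higher from compound 2 to compound 3 (within the scatter), in no particular direction. Compound 3 is estimated at 31%, with a range from 20% to 43%.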

Compound 3, a percentage reported as inhibition, in the whole organism at one dose (the size of the read-out at that dose, not a potency): 55.5%
Beside the measured number, compound 3's estimate is 24.5 percentage points below it; the measured number lies above the stated range.
By their numbers in this assay, from the lowest: compounds 1 and 2 (each within the scatter of the next); then compound 3.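

On the sulfonyl sulfur, the aryl group proves able to move the read-out in this assay: 3,4-dimethoxyphenyl in place of 4-methylphenyl gives a number 24.7 percentage points higher from compound 2 to compound 3 (beyond the scatter) in a series whose only earlier step, on the amine nitrogen, was flat. The change keeps the six-membered aromatic ring of carbon only and replaces the methyl group with two methoxy groups, so the step belongs to the groups carried on that ring rather than to the loss of the ring itself. Nothing measured here accounts for the size of this step.

Among these compounds, the single step changes both methoxy groups together, so it remains open whether 4-methoxyphenyl alone would carry the same gain. As far as these compounds go, it is also open whether an ethoxy group or a dimethylamino group on this ring would hold that level.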